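Bromo for Methoxy on the Pendant Aryl Ring

This account rests on a few compounds, and the source may have more. Where it says the series, first, only, none or still open, it means among the compounds named here.

compound 1, `COc1ccc(CCC2=C(Cl)C(=O)c3cc(OC)cc(OC)c3C2=O)cc1`: > 100000 nM
compound 2, `COc1ccc(CCC2=C(O)C(=O)c3cc(OC)cc(OC)c3C2=O)cc1`: 97500 nM

In a functional assay on NCI-H460 cells (Homo sapiens) for antiproliferative activity, read by MTT assay (a lower number here means a stronger inhibitor, a higher number a weaker inhibitor), compound 1 reaches only a limit, > 100000 nM. Within the data shown here, compound 2 gives 97500 nM, the only true number of the pair. The change an at least 1.0-fold lower number from compound 1 to compound 2 (0.01 log units; that floor lies within the scatter) stays within the scatter, with one partner sitting at the limit of > 100000 nM in this assay, at which 1 of the 2 values shown sits. Compound 3, `COc1cc(OC)c2c(c1)C(=O)C(O)=C(CCc1ccc(Br)cc1)C2=O`, differs from compound 2 by bromo in place of methoxy on an aromatic carbon. Among the measured compounds shown here, no measured step touches this position, so no shift beyond the scatter is expected in this assay. Compound 3 is therefore estimated at 80000 nM, ranging from 20000 nM to 300000 nM. That estimate corresponds to an expected 1.2-fold lower number from compound 2 to compound 3 (0.09 log units; within the scatter).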

Compound 3, half-maximal inhibitory concentration: > 100000 nM
Compound 3: only a limit was reported; the forecaster's own chance of this, stated with the estimate: 45%; middle value at least 1.2-fold (0.09 log units) from the limit.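

In this assay, among these compounds, the first change on the pendant aryl ring gives an at least 1.0-fold higher number from compound 2 to compound 3 (0.01 log units; that floor lies within the scatter), so replacing methoxy with bromo on this aromatic carbon gives no gain in potency that can be read. Compound 3 reports only a limit, so any larger loss stays hidden, and the scale's upper end now holds most of the series: the limit of > 100000 nM in this assay, at which 2 of the 3 values shown sit. The step from compound 1 to compound 2 had touched only a double-bonded ring carbon. Going by these compounds, it remains open whether an amine or carboxylic acid on this aromatic carbon, or a longer chain to the ring, would give a clearly lower number than compound 2.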